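Changing the aryl amine link in a pyridone-sulfone series

The source may report more compounds than this note shows. Statements on the series, on what has been measured and on what is new or still open speak of the compounds shown alone.

Measured compounds:
- compound 1, `Cn1c(=O)c(S(=O)(=O)c2ccc(F)cc2F)cc2cnc(Nc3ccc4[nH]c(C(=O)O)cc4c3)nc21`: 10000 nM
- compound 2, `CCCn1c(=O)c(S(=O)(=O)c2ccc(F)cc2F)cc2cnc(Nc3ccc4[nH]ccc4c3)nc21`: 1000 nM

Both compounds were tested in a functional assay on K562 cells (Homo sapiens) for inhibition, read by trypan blue exclusion, with a stated time of 72 h; a lower number here means a stronger inhibitor, a higher number a weaker inhibitor. Compound 1 has the highest number of the two, so it is the weaker inhibitor; compound 2 gives 1000 nM, a gap beyond the usual scatter. Among the measured compounds shown here, compound 2 differs from compound 1 in more than one place, so its values show only that a related compound without the acid reaches a lower number.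

Compound 3, `Cn1c(=O)c(S(=O)(=O)c2ccc(F)cc2F)cc2cnc(NCc3ccc4[nH]ccc4c3)nc21`, is not yet measured. It differs from compound 1 in one place: (1H-indol-5-yl)methyl in place of 2-carboxy-1H-indol-5-yl on a nitrogen on an aromatic ring. Based on compound 2, dropping the acid is expected to help compound 3 in this assay, while the inserted methylene is an untested change in this series, so compound 3 is expected to improve by a 3.3-fold lower number from compound 1 to compound 3 (0.52 log units; beyond the scatter). Compound 3 is thus estimated at 3000 nM, within a range of 700 nM to 15000 nM.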

Compound 3, half-maximal inhibitory concentration: 75000 nM
Beside the measured number, compound 3's estimate is 25-fold (1.40 log units) below it; the measured number lies above the stated range.
By their numbers in this assay, from the lowest: compound 2; then compound 1; then compound 3.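

Replacing 2-carboxy-1H-indol-5-yl with (1H-indol-5-yl)methyl on this nitrogen gives a 7.5-fold higher number from compound 1 to compound 3 (0.88 log units; beyond the scatter) in this assay and so weakens inhibition. Compound 3 carries no carboxylic acid, which shows that a compound without the acid does not always reach a lower number than compound 1: here the change at this one position moves the number the other way. Nothing shown here explains this loss, and the step cannot say whether it comes from losing the acid, from adding the methylene link, or from both together.

The two parts of the change remain unseparated, and 1H-indol-5-yl on the core of compound 1 would test the loss of the acid alone. Also open, as far as these compounds go, is how a longer chain, such as 2-(1H-indol-5-yl)ethyl, would behave on this nitrogen.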